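Swapping the indolyl for a pyrazolylphenyl: lipophilicity outlook

This account rests on a few compounds, and the source may have more. Where it says the series, first, only, none or still open, it means among the compounds named here.

Compound 1 `CN1CCN(CCCS(=O)(=O)c2ccc3nc(NC(=O)NC(=O)c4cc(C5CC5)ccc4Cl)sc3c2)CC1`: 2.9
Compound 2 `CN1CCN(CCCS(=O)(=O)c2ccc3nc(NC(=O)NC(=O)c4ccccc4Cl)sc3c2)CC1`: 1.8
Compound 3 `CN1CCN(CCCS(=O)(=O)c2ccc3nc(NC(=O)NC(=O)c4cc5c(ccn5C)cc4Cl)sc3c2)CC1`: 2.8

In a physicochemical assay for lipophilicity (a higher number here means a more lipophilic compound, a lower number a more polar compound), compound 3 gives 2.8, the second highest of the three numbers. Compound 1 stands nearest to it: a number 0.10 log units lower from compound 1 to compound 3 (within the scatter). Compound 2 stands furthest from it: a number 1.00 log units higher from compound 2 to compound 3 (beyond the scatter).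

Compound 4 `CN1CCN(CCCS(=O)(=O)c2ccc3nc(NC(=O)NC(=O)c4cccc(-n5cccn5)c4Cl)sc3c2)CC1` differs from compound 3 in one place: 2-chloro-3-(1H-pyrazol-1-yl)phenyl in place of 5-chloro-1-methyl-1H-indol-6-yl on a carbonyl carbon. Within the data shown here, two measured steps bear on this change. The step of a number 1.00 log units higher from compound 2 to compound 3 (beyond the scatter) shows that exchanging the group on this carbonyl carbon has shifted the number beyond the scatter, and the step of a number 1.10 log units lower from compound 1 to compound 2 (beyond the scatter) shows a shift of similar size for a change on the same group. Compound 4 carries the 2-chlorophenyl of compound 2 with a 1H-pyrazol-1-yl added, a change for which no measurement exists here. The expected step is therefore downward, a number 0.50 log units lower from compound 3 to compound 4 (beyond the scatter), beyond the scatter but smaller than the step to compound 2. The estimate for compound 4 is 2.3, within 1.8 to 2.8.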

Compound 4, distribution coefficient: 1.6
Estimate against measurement, compound 4: 0.70 log units above; the whole stated range lies above it.
By their numbers in this assay, from the lowest: compounds 4 and 2 (each within the scatter of the next); then compounds 3 and 1 (each within the scatter of the next).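

In this assay, among these compounds, the 1H-pyrazol-1-yl added to the 2-chlorophenyl of compound 2 gives a number 0.20 log units lower from compound 2 to compound 4 (within the scatter), so at this carbonyl carbon a group added to that ring need not move the number, whereas the cyclopropyl and the fused ring of the earlier compounds each did. A second aromatic ring on this group therefore does not by itself give a high number: the exchange for the 5-chloro-1-methyl-1H-indol-6-yl gives a number 1.20 log units lower from compound 3 to compound 4 (beyond the scatter), and the exchange for the 2-chloro-5-cyclopropylphenyl gives a number 1.30 log units lower from compound 1 to compound 4 (beyond the scatter). Nothing in the data accounts for this difference between the groups. The compounds shown leave open whether a phenyl or a 1H-imidazol-1-yl in place of the 1H-pyrazol-1-yl would stay level with compound 2 or approach compound 3. They also leave open what a methyl on the pyrazole ring would do.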